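The source may report more compounds than this note shows. Statements on the series, on what has been measured and on what is new or still open speak of the compounds shown alone.

Measured so far:
Compound 1 `COc1ccc2c(c1)OC(c1cc(OC)c(OC)c(OC)c1)C(C(=O)OC(C)C)=C2` gives 11800 nM in a functional assay for inhibition of nuclear factor NF-kappa-B complex (Homo sapiens); on this read-out lower numbers stand for stronger inhibition and higher numbers for weaker inhibition.
Compound 2 `CCOC(=O)C1=Cc2ccc(OC)cc2OC1c1cc(OC)c(OC)c(OC)c1` gives 25000 nM in this assay.
Compound 3 `COc1ccc2c(c1)OC(c1cc(OC)c(OC)c(OC)c1)C(C(=O)NC(C)C)=C2` gives > 50000 nM in this assay, which is a limit of the assay and not a number.

Compound 3 therefore stands at the top of the recorded range, with only a limit, as noted under (the limit of > 50000 nM in this assay, at which 1 of the 3 values shown sits). Compound 4 `CCNC(=O)C1=Cc2ccc(OC)cc2OC1c1cc(OC)c(OC)c(OC)c1` differs from compound 3 by hydrogen in place of methyl on a saturated chain carbon bound to an amide-type nitrogen and a saturated chain carbon. Within the data shown here, the one measured step of the same kind, on the ester side, is a 2.1-fold higher number from compound 1 to compound 2 (0.33 log units; beyond the scatter). The amide steps an at least 4.2-fold higher number from compound 1 to compound 3 (0.62 log units; beyond the scatter) and an at least 2.0-fold higher number from compound 2 to compound 3 (0.30 log units; that floor lies within the scatter) already end at the limit. Expected for the move from compound 3 to compound 4 is a small step or none beyond the scatter, a step that the limit leaves unreadable from compound 3 to compound 4. Compound 4 is estimated at 80000 nM, range 40000 nM to 200000 nM, most likely again reported only as a limit.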

Compound 4, half-maximal inhibitory concentration: > 50000 nM
Compound 4: only a limit was reported; the forecaster's own chance of this, stated with the estimate: 85%; the middle value lies beyond the limit too.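

In this assay compound 4 gives > 50000 nM, a limit of the assay and not a number, so isopropylamino to ethylamino brings no measured number back on the amide side. Ethylamino in place of ethoxy reads as an at least 2.0-fold higher number from compound 2 to compound 4 (0.30 log units; that floor lies within the scatter), and ethylamino in place of isopropoxy as an at least 4.2-fold higher number from compound 1 to compound 4 (0.62 log units; beyond the scatter). The step between the two amides cannot be read, because both sit at the same limit: the limit of > 50000 nM in this assay, at which 2 of the 4 values shown sit.

Still open, from the compounds shown here alone, is how far apart the two amides lie. Also open, going by these compounds, is whether a carboxylic acid or a butyl ester on the carbonyl carbon gives a number within the read-out.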